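Chain extension on the alkyl amide of compound 3

The compounds below may be only part of what the source reports. "The series", "measured", "known", "first", "only" and "open" are said of these compounds alone.

Compound 3 `C/C=C/C=C/C(=O)N[C@H](C(=O)NCCCCCCCC)[C@@H](C)O` stands second highest of three in a functional assay on HepG2 cells (Homo sapiens) for cytotoxicity, read by MTT assay, with a stated time of 48 h (on this read-out higher numbers stand for weaker inhibition and lower numbers for stronger inhibition), where compound 3 gives 102000 nM; compound 2 `CCCCCCCCNC(=O)[C@@H](NC(=O)c1cc2ccccc2o1)[C@@H](C)O` gives 81300 nM and compound 1 `CCCCCCCCNC(=O)[C@@H](NC(=O)c1ccccc1)[C@@H](C)O` gives 136000 nM. The measured steps, a 1.7-fold lower number from compound 1 to compound 2 (0.22 log units; within the scatter), a 1.3-fold lower number from compound 1 to compound 3 (0.12 log units; within the scatter) and a 1.3-fold higher number from compound 2 to compound 3 (0.10 log units; within the scatter), all lie within the scatter and all vary the acyl group on the carbonyl carbon. Compound 4 `C/C=C/C=C/C(=O)N[C@H](C(=O)NCCCCCCCCCCCCCCCCCC)[C@@H](C)O` differs from compound 3 by decyl in place of hydrogen on a saturated chain carbon, eight bonds along the chain from an amide-type nitrogen. Among the compounds with values here, no measured step changes the alkyl chain on the amide nitrogen, so nothing bears directly on this change. Without a precedent, no step beyond the scatter is expected in this assay, but with wide uncertainty. Compound 4 is estimated at 80000 nM (range 12000 nM to 300000 nM), an expected step of a 1.3-fold lower number from compound 3 to compound 4 (0.11 log units; within the scatter).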

Compound 4, half-maximal inhibitory concentration: 284000 nM
Compound 4: middle estimate off by 3.6-fold (0.55 log units), on the low side; low and high end bracket the measured number.
By their numbers in this assay, from the lowest: compounds 2, 3 and 1 (each within the scatter of the next); then compound 4.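

Within the data shown here, the alkyl chain on the amide nitrogen is the first place where a change moves the number beyond the scatter: in this assay decyl in place of hydrogen on a saturated chain carbon gives a 2.8-fold higher number from compound 3 to compound 4 (0.44 log units; beyond the scatter) while the acyl changes among compound 1, compound 2 and compound 3 all stay within it. The step is toward weaker inhibition, and no measurement on hand accounts for it.

Still open, as far as these compounds go, is how the number moves with chains shorter than this one, and whether an amine or a carboxylic acid at the chain end would act as the plain chain does. From the compounds shown here alone, whether the same extension holds with the acyl groups of compound 1 and compound 2 is also open.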